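Adding One Methoxy Group to Compound 2

The source may hold more compounds than are shown below. What is called first, only, known or untested is meant among the compounds shown, and "the series" means these compounds.

Measured in a functional assay on MDA-MB-453 cells (Homo sapiens) for cytotoxicity; on this read-out lower numbers stand for stronger inhibition of growth and higher numbers for weaker inhibition of growth:
- Compound 1 (`COc1ccc(C23OCC24C(CO)C4Cc2cc(OC)c(OC)cc23)cc1OC`): > 100000 nM (a limit)
- Compound 2 (`COc1ccc(C23OCC24C2COC(c5cc(OC)c(OC)cc53)C24)cc1OC`): > 100000 nM (a limit)

Compound 2 gives only a limit of > 100000 nM in this assay, not an exact number. The two compounds share that position (the limit of > 100000 nM in this assay, at which 2 of the 2 values shown sit), so neither can be ranked against the other. Compound 3 (`COc1cc2c(cc1OC)C1(c3cc(OC)c(OC)c(OC)c3)OCC13C1COC2C13`) differs from compound 2 by one structural change (methoxy in place of hydrogen on an aromatic carbon): methoxy in place of hydrogen on an aromatic carbon. Among the measured compounds shown here, no measured pair shows the effect of this change, so no step beyond the usual scatter is expected in this assay, and compound 3 will probably stay at the limit too. The expected step is (a number no higher from compound 2 to compound 3 (the limit leaves the size open)) on this estimate. Compound 3 is estimated at 100000 nM, with an expected range from 30000 nM to 300000 nM in this measurement.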

Compound 3, concentration for 50% growth inhibition: 19500 nM
Beside the measured number, compound 3's estimate is 5.1-fold (0.71 log units) above it; the measured number lies below the stated range.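

In this assay, methoxy in place of hydrogen on an aromatic carbon gives an at least 5.1-fold lower number from compound 2 to compound 3 (0.70 log units; beyond the scatter), which shows that growth inhibition in these cells can respond to a change at this position, ortho to a methoxy group and meta to a large group. Until now, the compounds offered no sign that any change to this shared core could register in this read-out. Compound 3 is the only compound shown with an exact number, and the others remain at a limit: the limit of > 100000 nM in this assay, at which 2 of the 3 values shown sit.

Going by these compounds, whether methoxy itself matters here remains open, and a hydroxyl group, a chlorine atom or a longer ethoxy chain on the same carbon could help to settle that. On these data alone, the full size of the step also remains unknown, as does whether the same methoxy would have a similar effect on the core of compound 1.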